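This account rests on a few compounds, and the source may have more. Where it says the series, first, only, none or still open, it means among the compounds named here.

Measured in a functional assay on QGY7701 cells (Homo sapiens) for cytotoxicity, read by MTT assay, with a stated time of 24 h; a lower number here means a stronger inhibitor, a higher number a weaker inhibitor:

Compound 1, `C=CC1=C(C(=O)NCc2ccc(Cl)cc2)C(c2ccc(F)cc2)OC1`, gives 36900 nM.
Compound 2, `C=CC1=C(C(=O)NCC(C)C)C(c2ccc(Cl)c(Cl)c2)OC1`, reaches only a limit of the assay, > 100000 nM.
Compound 3, `C=CC1=C(C(=O)NCc2ccc(Cl)cc2)C(c2ccc(OC)cc2)OC1`, likewise reaches only a limit, > 100000 nM.

Among the measured compounds shown here, compound 1 is thus the only compound with an actual number in this assay; the other two sit at the limit of > 100000 nM in this assay, at which 2 of the 3 values shown sit, so the set gives a single fixed point. For the measured compounds named here, the one measured step, an at least 2.7-fold higher number from compound 1 to compound 3 (0.43 log units; beyond the scatter), replaced a group on the aromatic ring attached directly to the shared core and weakened the compound to the limit.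

Compound 4, `C=CC1=C(C(=O)NCc2ccccc2)C(c2ccc(F)cc2)OC1`, differs from compound 1 at a different place: hydrogen in place of chloro on an aromatic carbon. Going by the values given here, this change sits on the benzyl group of the amide, a part of the molecule that no measured step has touched, so the step from compound 1 to compound 3 tells nothing directly about it. Removing a group is also a smaller alteration than the exchange measured there. Among the compounds with values here, with no comparable step, the expectation is a modest weakening at most, estimated as a 1.5-fold higher number from compound 1 to compound 4 (0.17 log units; within the scatter), which may well fall within the scatter. Compound 4 is therefore expected to give about 55000 nM in this assay, with a likely range from 20000 nM to 150000 nM.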

Compound 4, half-maximal inhibitory concentration: 67600 nM
Compound 4: middle estimate off by 1.2-fold (0.09 log units), on the low side, and the stated range covers the measured number.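

In this assay, among the compounds shown here, the first change to the benzyl group on the amide gives a 1.8-fold higher number from compound 1 to compound 4 (0.26 log units; within the scatter), so at this position, para to a large group, chloro and hydrogen cannot be told apart. This differs from the change on the other aromatic ring, which gives an at least 2.7-fold higher number from compound 1 to compound 3 (0.43 log units; beyond the scatter) and, unlike the step to compound 4, lies beyond the scatter. Compound 4 also yields an actual number, so compound 1 is no longer the only fixed point in a set where the other values are only a limit: the limit of > 100000 nM in this assay, at which 2 of the 4 values shown sit.

With just chloro and hydrogen shown at this position, it remains open whether a larger change here, such as a methoxy group, an amine or a carboxylic acid on the ring, would move the number beyond the scatter. Also open, as far as these compounds go, are the effect of a longer chain between the amide and its ring and the separate contributions of the amide group and ring substituents in compound 2, which differs from compound 1 in more than one place.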